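This account rests on a few compounds, and the source may have more. Where it says the series, first, only, none or still open, it means among the compounds named here.

Measured so far:
Compound 1, `CCSc1nc(N)c2nc(O)n(Cc3ccccc3)c2n1`, in a functional assay (spleen, spleen) for activation, with Mus musculus as the target; on this read-out lower numbers stand for an effect already at smaller amounts and higher numbers for an effect only at larger amounts of compound: 0.1 uM
Compound 2, `Nc1ncnc2c1nc(O)n2Cc1ccccc1`, in this assay: 10 uM

Among the measured compounds shown here, of these two compounds, compound 2 gives the higher number in this assay; its nearest neighbour is compound 1, and the single measured step, a 100-fold higher number from compound 1 to compound 2 (2.00 log units; beyond the scatter), lies between them and is well beyond the scatter. The change now followed runs from compound 2 to compound 3, `CCc1nc(N)c2nc(O)n(Cc3ccccc3)c2n1`: ethyl in place of hydrogen on an aromatic carbon. For the measured compounds named here, the only step that bears on it is the one from compound 1, where loss of the ethylsulfanyl group gave a 100-fold higher number from compound 1 to compound 2 (2.00 log units; beyond the scatter). The new change places a group on the same aromatic carbon, so a step in the opposite direction is the natural expectation, although ethyl is not ethylsulfanyl and the whole of that difference need not be recovered. The author therefore expects for compound 3 a lower number than for compound 2, with a 20-fold lower number from compound 2 to compound 3 (1.30 log units; beyond the scatter) as the estimated step. Going by the values given here, compound 3 is estimated at 0.5 uM, within 0.1 uM to 3 uM, the wide range reflecting that only one step informs the estimate.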

Compound 3, minimum effective concentration: 1 uM
For compound 3 the middle estimate is 2.0-fold (0.30 log units) below the measured one; measured number inside the range.
By their numbers in this assay, from the lowest: compound 1; then compound 3; then compound 2.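

In this assay, the aromatic carbon between two ring nitrogen atoms now has a second substituent to set against hydrogen: ethyl in place of hydrogen gives a 10-fold lower number from compound 2 to compound 3 (1.00 log units; beyond the scatter) and so lowers the number without any sulfur atom in the group. Ethyl does not fully stand in for ethylsulfanyl, however, since replacing one with the other gives a 10-fold higher number from compound 1 to compound 3 (1.00 log units; beyond the scatter) and leaves compound 3 with a number between those of the other two compounds. The span from hydrogen to ethylsulfanyl thus divides into two steps of the same printed size, but nothing at hand explains either of them.

The compounds shown leave open how a propyl chain, a methylsulfanyl group or an amine on this same carbon would stand against ethyl and ethylsulfanyl. They also leave open whether the order of hydrogen, ethyl and ethylsulfanyl would hold if a cyclohexylmethyl group took the place of the benzyl group on the shared core.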